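Swapping Trifluoromethyl for Dimethylamino on the Shared Core

The source may report more compounds than this note shows. Statements on the series, on what has been measured and on what is new or still open speak of the compounds shown alone.

Compound 1, `Cc1c(C(=O)NCc2cccc(C(F)(F)F)c2)cnn1-c1ccc(F)cc1`: 790 nM
Compound 2, `Cc1c(C(=O)NCc2cccc(C(F)(F)F)c2)cnn1-c1ccc([N+](=O)[O-])cc1`: 960 nM
Compound 3, `O=C(NCc1cccc(C(F)(F)F)c1)c1cnn(-c2ccc(Cl)cc2)c1C(F)(F)F`: > 3000 nM

In a functional assay on cells for antagonist activity at C-C chemokine receptor type 1 (Homo sapiens), read by FLIPR and calcium flux (a higher number here means a weaker inhibitor, a lower number a stronger inhibitor), compound 1 gives 790 nM and compound 2 gives 960 nM; the step of a 1.2-fold higher number from compound 1 to compound 2 (0.08 log units; within the scatter) lies within the scatter. For compound 3 the value > 3000 nM is a limit of the assay, not a number. Compound 3 thus stands at the limit of > 3000 nM in this assay, at which 1 of the 3 values shown sits.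

Compound 4, `CN(C)c1c(C(=O)NCc2cccc(C(F)(F)F)c2)cnn1-c1ccc(Cl)cc1`, differs from compound 3 by dimethylamino in place of trifluoromethyl on an aromatic carbon. Among the measured compounds shown here, no measured step bears on this change; the one step, a 1.2-fold higher number from compound 1 to compound 2 (0.08 log units; within the scatter), concerns a different ring. Compounds 1 and 2 carry methyl at this place and give numbers rather than limits. Compound 4 is estimated at 1500 nM, between 400 nM and 6000 nM. The expected step is an at least 2.0-fold lower number from compound 3 to compound 4 (0.30 log units; that floor lies within the scatter), with a fair chance that only a limit is reported.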

Compound 4, half-maximal inhibitory concentration: > 3000 nM
Compound 4: a limit, no number; the forecaster's own chance of this, stated with the estimate: 35%; at least 2.0-fold (0.30 log units) between middle value and limit.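

In this assay compound 3 and compound 4 both give a limit and not a number, so no step can be read between them: the limit of > 3000 nM in this assay, at which 2 of the 4 values shown sit.

The compounds shown leave open whether dimethylamino in place of trifluoromethyl changes the inhibition at all.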